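The source may report more compounds than this note shows. Statements on the series, on what has been measured and on what is new or still open speak of the compounds shown alone.

Measured in a functional assay on HepG2 cells (Homo sapiens) for inhibition, read by MTT assay (on this read-out higher numbers stand for weaker inhibition of growth and lower numbers for stronger inhibition of growth), as follows:
compound 1 `COc1cc2oc(-c3cccc(NC(=O)c4ccccc4Br)c3)cc(=O)c2c(OC)c1OC` gives 23100 nM
compound 2 `COc1cc2oc(-c3cccc(NC(=O)c4cccc(C#N)c4)c3)cc(=O)c2c(OC)c1OC` gives 11900 nM

Compound 2 and compound 1 lie within the scatter of each other, so these numbers do not rank them. Compound 3 `COc1ccc(C(=O)Nc2cccc(-c3cc(=O)c4c(OC)c(OC)c(OC)cc4o3)c2)cc1` shares the core of compound 2 and carries 4-methoxyphenyl in place of 3-cyanophenyl on a carbonyl carbon. Among the compounds with values here, one measured step bears on this change: a 1.9-fold lower number from compound 1 to compound 2 (0.29 log units; within the scatter) with 3-cyanophenyl in place of 2-bromophenyl, also on a carbonyl carbon. Within the data shown here, that step is small and no measured compound carries 4-methoxyphenyl, so no step beyond the scatter is expected in this assay and no direction can be given. The expected change is a 1.3-fold higher number from compound 2 to compound 3 (0.10 log units; within the scatter) by this estimate. Compound 3 is estimated at 15000 nM with 6000 nM to 40000 nM as its expected range.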

Compound 3, concentration for 50% growth inhibition: 22200 nM
Compound 3: middle estimate off by 1.5-fold (0.17 log units), on the low side, within the range that was stated.
By their numbers in this assay, from the lowest: compounds 2, 3 and 1 (each within the scatter of the next).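

In this assay, 4-methoxyphenyl on a carbonyl carbon gives a 1.9-fold higher number from compound 2 to compound 3 (0.27 log units; within the scatter), and set against 2-bromophenyl it gives a 1.0-fold lower number from compound 1 to compound 3 (0.02 log units; within the scatter). Each of the three groups now tested at this place lies within the scatter of the other two, so the change to 4-methoxyphenyl separates compound 3 from neither compound 1 nor compound 2, and the three substituted phenyl groups remain unranked. No evidence at hand bears on why these groups read alike.

As far as these compounds go, all three compounds keep a substituted phenyl on the carbonyl carbon, so it remains open whether a different kind of group there, such as a piperidine, a carboxylic acid or a longer alkyl chain, would give a step beyond the scatter. The compounds shown also leave open whether changing the methoxy groups on the shared core would alter the number.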